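This account rests on a few compounds, and the source may have more. Where it says the series, first, only, none or still open, it means among the compounds named here.

Compound 1 `CC(C)C(c1ncco1)c1ccc(-c2ccc3cccc(F)c3c2)[nH]c1=O` gives 0.0983 h in an ADME assay on microsomes from liver (Rattus norvegicus) for metabolic stability (a higher number here means that the compound lasts longer, a lower number that the compound disappears faster), the smallest of the three numbers, though compound 2 `CC(C)C(Cc1nnc[nH]1)c1ccc(-c2ccc3cccc(F)c3c2)[nH]c1=O` with 0.1 h and compound 3 `CC(C)C(c1ccc(-c2ccc3cccc(F)c3c2)[nH]c1=O)N1CCCCC1=O` with 0.102 h sit within the scatter of it: a 1.0-fold higher number from compound 1 to compound 2 (0.01 log units; within the scatter) and a 1.0-fold higher number from compound 1 to compound 3 (0.02 log units; within the scatter). Compound 4 `CC(C)C(Cc1nnn[nH]1)c1ccc(-c2ccc3cccc(F)c3c2)[nH]c1=O` differs from compound 1 in one place: (1H-tetrazol-5-yl)methyl in place of 1,3-oxazol-2-yl on a saturated chain carbon bound to an aromatic carbon and a saturated chain carbon. The two measured exchanges at the same saturated chain carbon both left the half-life unchanged within the scatter, so for this exchange too no step beyond the scatter is expected in this assay in either direction; the expected step is a 1.0-fold higher number from compound 1 to compound 4 (0.01 log units; within the scatter). For compound 4 the half-life is accordingly estimated at 0.1 h, with a range of 0.05 h to 0.2 h.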

Compound 4, half-life: 2.08 h
Beside the measured number, compound 4's estimate is 21-fold (1.32 log units) below it; the whole stated range lies below it.
By their numbers in this assay, from the lowest: compounds 1, 2 and 3 (each within the scatter of the next); then compound 4.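

At this saturated chain carbon the half-life in this assay does respond to the group carried there: a 21-fold higher number from compound 1 to compound 4 (1.33 log units; beyond the scatter), and a 20-fold higher number from compound 3 to compound 4 (1.31 log units; beyond the scatter). With the chain carbon kept, the exchange of 4H-1,2,4-triazol-3-yl for 1H-tetrazol-5-yl alone gives a 21-fold higher number from compound 2 to compound 4 (1.32 log units; beyond the scatter), so the methyl link by itself does not account for the step. Nothing available gives a reason for this step. On these data alone, it remains open whether the step is specific to the tetrazole ring: a carboxylic acid on the same carbon would test that, and a longer chain carrying the 1H-tetrazol-5-yl would show how far the ring can move.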